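The compounds below may be only part of what the source reports. "The series", "measured", "known", "first", "only" and "open" are said of these compounds alone.

Measured compounds:

Compound 1, `CCN1CCN(c2cccc3c2C[C@H](CN(C)[C@H]2CCCc4cccnc42)NC3)CC1`. In a functional assay on CCRF-CEM cells for agonist activity at C-X-C chemokine receptor type 4 (Homo sapiens), read by calcium flux, with a stated time of 25 min (a lower number here means that less compound is needed, a higher number that more compound is needed for the effect), compound 1 gives > 30000 nM, which is a limit of the assay rather than a number.
Compound 2, `CN(C[C@H]1Cc2c(cccc2N2C[C@@H]3C[C@H]2CN3)CN1)[C@H]1CCCc2cccnc21`. In this assay compound 2 gives > 30000 nM, again a limit.
Compound 3, `CN(C[C@H]1Cc2c(cccc2N2C[C@H]3C[C@@H]2CN3)CN1)[C@H]1CCCc2cccnc21`. In this assay compound 3 gives > 30000 nM, also a limit.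

Compound 3 therefore stands at the limit, and so do the two other values shown; no numbered result exists anywhere in the set. The steps a step that the two limits leave unreadable from compound 1 to compound 2, a step that the two limits leave unreadable from compound 1 to compound 3 and a step that the two limits leave unreadable from compound 2 to compound 3 cannot be sized, due to the limit of > 30000 nM in this assay, at which 3 of the 3 values shown sit. For the last of these, the fact that compounds 2 and 3 differ only in the configuration as drawn means that even the configurational change between the two bridged compounds leaves no readable mark at this limit.

Compound 4, `CN(C[C@H]1Cc2c(cccc2N2CCNCC2)CN1)[C@H]1CCCc2cccnc21`, differs from compound 3 in that (a group of 6 heavy atoms (4 carbon, 2 nitrogen; one six-membered non-aromatic ring with 2 hetero atoms) in place of a group of 7 heavy atoms (5 carbon, 2 nitrogen; 2 five-membered non-aromatic rings with 1 hetero atom each), on an aromatic carbon). The ring that enters is of the same six-membered kind that compound 1 carries on the same aromatic carbon, and compound 1 also sits at the limit. Within the data shown here, no measured step gives a readable size or direction, so no step beyond the scatter can be predicted, and the most likely outcome is a further limit. Compound 4 is expected at 30000 nM, with a range from 10000 nM to 100000 nM. The expected step of a number no higher from compound 3 to compound 4 (the limit leaves the size open) is accordingly estimated as nil within what the limits allow.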

Compound 4, half-maximal effective concentration: > 30000 nM
Compound 4 ended at the assay's limit (the forecaster's own chance of this, stated with the estimate: 85%); the middle value lies on the limit itself.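

No new step can be read between compound 4 and compound 1, compound 2 or compound 3, for one reason common to all of them: the limit of > 30000 nM in this assay, at which 4 of the 4 values shown sit.

The compounds shown leave open how far each lies beyond the limit, and so whether the ethyl on the ring amine nitrogen, the bridged group or its configuration changes the result in this assay at all.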